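A few compounds are considered here, and "the series" means these few. Any claim that something is new, unique, unknown or untested is made for them only; others in the source may bear on it.

Measured compounds:
- compound 1, `CCCCCCCCS(=O)(=O)Nc1cc(-c2cccc(Cl)c2)ccc1C(=O)O`: 13800 nM
- compound 2, `CCCCCCCCS(=O)(=O)Nc1cc(-c2ccccc2-c2ccccc2)ccc1C(=O)O`: 17100 nM

Both numbers come from an assay on mitochondria (strain BALB/c) for inhibition of glycerol-3-phosphate acyltransferase 1, mitochondrial (Mus musculus), read by scintillation counting, with a stated time of 10 min; on this read-out lower numbers stand for stronger inhibition and higher numbers for weaker inhibition. On this read-out compound 2 gives the higher of the two numbers, yet its gap to compound 1 is within the usual scatter of repeated measurements, so the two compounds cannot be told apart on these data.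

Compound 3, `CCCCCCCCS(=O)(=O)Nc1cc(-c2ccccc2F)ccc1C(=O)O`, is the next compound in line and has not been measured. Set against compound 2, the change is fluoro in place of phenyl on an aromatic carbon: the second ring that hangs from the outer ring of compound 2 is gone, and a single fluorine atom sits in its place, ortho to a large group. Among the compounds with values here, no pair of measured compounds that differ in only one place is available, so there is no measured step to lean on. Given that compound 1 and compound 2 carry different outer rings and still land close together, the step from compound 2 to compound 3 is expected to be small, with no direction beyond the scatter, as a 1.1-fold lower number from compound 2 to compound 3 (0.06 log units; within the scatter) expresses. Compound 3 is therefore estimated at 15000 nM in this assay, with a range from 5000 nM to 45000 nM.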

Compound 3, half-maximal inhibitory concentration: 47200 nM
Beside the measured number, compound 3's estimate is 3.1-fold (0.50 log units) below it; measured number outside the range, above it.
By their numbers in this assay, from the lowest: compounds 1 and 2 (each within the scatter of the next); then compound 3.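

In this assay, fluoro in place of phenyl on this aromatic carbon gives a 2.8-fold higher number from compound 2 to compound 3 (0.44 log units; beyond the scatter) and so shows that what sits at this place can matter, which compounds 1 and 2 alone could not show. Measured against the other compound, 2-fluorophenyl in place of 3-chlorophenyl gives a 3.4-fold higher number from compound 1 to compound 3 (0.53 log units; beyond the scatter) in the same direction, which makes compound 3 the weakest inhibitor of the three, while compounds 1 and 2 remain within the scatter of each other. Nothing in the available data accounts for this shift in either step.

The compounds shown leave open whether the shift belongs to the phenyl that leaves or to the fluoro that enters, and a plain hydrogen, a chloro or a methoxy on that same carbon would help to separate the two. They also leave open whether a step of this kind would hold with a shorter chain in place of the octyl chain, or with another group in place of the carboxylic acid on the shared core.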